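Shifting the acyl aryl in a trifluoromethylthiazole acylurea series

The compounds below may be only part of what the source reports. "The series", "measured", "known", "first", "only" and "open" are said of these compounds alone.

Compound 1 `CN(C(=O)NC(=O)c1cccc(C(F)(F)F)c1)c1nc(C(F)(F)F)c(C(=O)N/N=C/c2cccc(C(F)(F)F)c2)s1` was tested in a functional assay on A549 cells (Homo sapiens) for inhibition, read by MTT assay, with a stated time of 72 h (on this read-out higher numbers stand for weaker inhibition and lower numbers for stronger inhibition), where compound 1 gives 8.16 ug/mL. Its nearest companion is compound 2 `CN(C(=O)NC(=O)c1cccc(C(F)(F)F)c1)c1nc(C(F)(F)F)c(C(=O)N/N=C/c2ccccc2C(F)(F)F)s1`, which in this assay gives 12.1 ug/mL; the move a 1.5-fold higher number from compound 1 to compound 2 (0.17 log units; within the scatter) is within the scatter, so the two numbers stand together rather than in order. Compound 3 `CN(C(=O)NC(=O)c1ccc(C(F)(F)F)cc1)c1nc(C(F)(F)F)c(C(=O)N/N=C/c2ccc(C(F)(F)F)cc2)s1` reaches only a limit in this assay, > 100 ug/mL, and that value is a limit of > 100 ug/mL in this assay, at which 1 of the 3 values shown sits, rather than a number.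

Compound 4 `CN(C(=O)NC(=O)c1ccccc1F)c1nc(C(F)(F)F)c(C(=O)N/N=C/c2cccc(C(F)(F)F)c2)s1` differs from compound 1 in one place: 2-fluorophenyl in place of 3-(trifluoromethyl)phenyl on a carbonyl carbon. Among the measured compounds shown here, the only measured step, from compound 1 to compound 2, lies on the carbon with a double bond to nitrogen, not on the carbonyl carbon, so no measured step bears directly on this change. Compound 3 differs from compound 1 in two places, so its limit cannot be read as a single step.

For the measured compounds named here, with no direct precedent, the expected step of a 1.5-fold higher number from compound 1 to compound 4 (0.17 log units; within the scatter) is estimated to stay within the scatter, with wide uncertainty. Compound 4 is therefore expected to give 12 ug/mL, ranging from 4 ug/mL to 45 ug/mL.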

Compound 4, half-maximal inhibitory concentration: 19.5 ug/mL
For compound 4 the middle estimate is 1.6-fold (0.21 log units) below the measured one; the measured number falls inside the stated range.
By their numbers in this assay, from the lowest: compounds 1, 2 and 4 (each within the scatter of the next, the first and the last beyond it). At a limit, above all of these: compound 3.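

In this assay, the carbonyl carbon gets its first measured step: placing 2-fluorophenyl there in place of 3-(trifluoromethyl)phenyl gives a 2.4-fold higher number from compound 1 to compound 4 (0.38 log units; beyond the scatter) as a modest change. Among the compounds shown here, the only earlier single-place step, a 1.5-fold higher number from compound 1 to compound 2 (0.17 log units; within the scatter) on the carbon with a double bond to nitrogen, stayed within the scatter, so the acyl aryl is the first place in this set where a single change moves the number beyond it. Nothing measured here accounts for this step.

The change swaps the substituent and its place on the ring together, and the compounds shown do not separate these two. Going by these compounds, how an aryl bearing an amine or a carboxylic acid, or a longer alkyl chain, would read on this carbonyl carbon also remains open.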